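Swapping Fluoro for Difluoromethoxy on a Benzyl Arm

The compounds below may be only part of what the source reports. "The series", "measured", "known", "first", "only" and "open" are said of these compounds alone.

Compound 1 `Cc1ccc2[nH]c(=O)c(CN(Cc3ccc(F)cc3)Cc3ccc(C(C)(C)C)cc3)cc2c1` was run in a toxicity assay on MDCK cells (Canis lupus familiaris) for cytotoxicity, read by crystal violet staining, with a stated time of 48 h; a lower number here means that less compound is tolerated, a higher number that more compound is tolerated. In this assay compound 1 gives > 27000 nM, which is a limit of the assay rather than a number. Compound 2 `Cc1ccc2[nH]c(=O)c(CN(Cc3ccc(F)cc3)Cc3cccc4ccccc34)cc2c1` carries naphthalen-1-yl in place of 4-(tert-butyl)phenyl on a saturated chain carbon bound to an amine nitrogen. In this assay compound 2 gives > 5000 nM, again a limit. The step that the two limits leave unreadable from compound 1 to compound 2 cannot be read in size because the limit of > 27000 nM in this assay, at which 1 of the 2 values shown sits, and the limit of > 5000 nM in this assay, at which 1 of the 2 values shown sits, are both limits. Compound 3 `Cc1ccc2[nH]c(=O)c(CN(Cc3ccc(OC(F)F)cc3)Cc3ccc(C(C)(C)C)cc3)cc2c1` differs from compound 1 by difluoromethoxy in place of fluoro on an aromatic carbon. Among the measured compounds shown here, no measured step touches this change, and the two values shown are only limits, so no step beyond the scatter is expected. Compound 3 is therefore estimated to give about 27000 nM, within a range from 10000 nM to 60000 nM, quite possibly again as a limit. The step of a number no higher from compound 1 to compound 3 (the limit leaves the size open) that this estimate means is expected to be small.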

Compound 3, half-maximal cytotoxic concentration: > 5000 nM
Compound 3 gave a limit, no number; the forecaster's own chance of this, stated with the estimate: 70%; the middle value does not contradict the limit.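

Compound 1 and compound 3 both stand at limits in this assay rather than at numbers, and no step can be read between them. The compounds shown leave open whether difluoromethoxy in place of fluoro changes how much compound is tolerated, and by how much.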